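This account rests on a few compounds, and the source may have more. Where it says the series, first, only, none or still open, it means among the compounds named here.

Three compounds have been measured in a functional assay on the whole organism for inhibition, with Rattus norvegicus as the target, with a stated time of 5 min, at a dose of 3 mg/kg by the oral route; on this read-out lower numbers stand for less inhibition and higher numbers for more inhibition at the one dose given (going by the name of the read-out):

Compound 1 `Cc1cccc(C(=O)Nc2nn[nH]n2)n1` gives 73%
Compound 2 `Cc1cc(Cl)cc(C(=O)Nc2nn[nH]n2)n1` gives 85%
Compound 3 `O=C(Nc1nn[nH]n1)c1cccc(/C=C/c2ccccc2)n1` gives 75%

Compound 1 stands lowest of the three numbers. Compound 3 lies within the scatter of it, so nothing separates the two. Among the compounds with values here, compound 2 lies beyond the scatter, and the one step that can be followed, a number 12 percentage points higher from compound 1 to compound 2 (beyond the scatter), is a modest rise brought about by chloro in place of hydrogen on an aromatic carbon.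

Compound 4 `Cc1ccc(C)c(C(=O)Nc2nn[nH]n2)n1` differs from compound 1 by methyl in place of hydrogen on an aromatic carbon. Within the data shown here, no measured pair shows a methyl entering in this way, so the only step that bears on the change is the one from compound 1 to compound 2, where a chloro group on the same core gave a modest rise. Among the measured compounds shown here, a methyl entering on an aromatic carbon is a change of comparable size in heavy atoms but not the same group, and the one step available does not show that any small substituent on that ring moves the number. The expectation for compound 4 is therefore a step of a number 3 percentage points higher from compound 1 to compound 4 (within the scatter) in this assay, not clearly beyond the scatter. Compound 4 is estimated at 76%, with a range from 62% to 88%.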

Compound 4, a percentage reported as inhibition, in the whole organism at one dose (the size of the read-out at that dose, not a potency): 72%
Estimate against measurement, compound 4: 4 percentage points above, and the stated range covers the measured number.
By their numbers in this assay, from the lowest: compounds 4, 1, 3 and 2 (each within the scatter of the next, the first and the last beyond it).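

In this assay, a methyl group on an aromatic carbon, ortho to a group of 8 heavy atoms and two atoms from the ring nitrogen, gives a number 1 percentage points lower from compound 1 to compound 4 (within the scatter), so at this place the added methyl does not separate compound 4 from compound 1. Within the data shown here, until now the shared core offered only one step, a number 12 percentage points higher from compound 1 to compound 2 (beyond the scatter), and the new result shows that a substituent entering on this ring does not always give a step beyond the scatter. The two steps differ both in the group that enters and in the carbon that carries it, so they cannot show which of these two differences sets them apart, and nothing measured here offers an explanation for the result.

The compounds shown leave open whether a chloro group on this same carbon, or a methyl group on the carbon that carries chloro in compound 2, would give a step beyond the scatter. They also leave open whether an amine, a methoxy group or a longer chain at this place would move the number at this single dose.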